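Truncating the longer chain on compound 1's outer ring

The compounds below may be only part of what the source reports. "The series", "measured", "known", "first", "only" and "open" are said of these compounds alone.

The series shares a flavanone-type core carrying a 3-methylbut-2-en-1-yl group; compound 1 `CC(C)=CCC/C(C)=C/Cc1cc([C@@H]2CC(=O)c3c(cc(O)c(CC=C(C)C)c3O)O2)ccc1O` bears the longer 3,7-dimethylocta-2,6-dien-1-yl chain on its outer ring. For the measured compounds named here, in a functional assay on A2780 cells (Homo sapiens) for cytotoxicity (on this read-out lower numbers stand for stronger inhibition and higher numbers for weaker inhibition), compound 1 gives 10 ug/mL, which is the second highest of the three numbers so far. Compound 2 `CC(C)=CCC/C(C)=C/Cc1cc([C@@H]2CC(=O)c3c(cc(O)c(CC=C(C)C)c3O)O2)cc(O)c1O` gives 11 ug/mL, and the step of a 1.1-fold higher number from compound 1 to compound 2 (0.04 log units; within the scatter). Going by the values given here, compound 3 `CC(C)=CCC/C(C)=C/Cc1c(O)cc2c(c1O)C(=O)C[C@@H](c1ccc(O)c(O)c1)O2`, in which the chains sit on different rings, gives 5.5 ug/mL; the two values of compound 1 and compound 3 are within the scatter of each other, and no single-point step connects them.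

Compound 4 `CC(C)=CCc1cc([C@@H]2CC(=O)c3c(cc(O)c(CC=C(C)C)c3O)O2)ccc1O` differs from compound 1 by hydrogen in place of 3-methylbut-2-en-1-yl on a saturated chain carbon bound to a double-bonded chain carbon. Among the compounds with values here, no measured step touches this chain, so no direct precedent exists; the only single-point step, the hydroxy addition in the step from compound 1 to compound 2, was within the scatter and concerns a different part of the molecule. The expectation for compound 4 is therefore a number near that of compound 1, with the step of a 1.4-fold higher number from compound 1 to compound 4 (0.15 log units; within the scatter) not expected to exceed the scatter by much, if at all. For compound 4 the estimated value in this assay is 14 ug/mL, within the expected range 6 ug/mL to 35 ug/mL.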

Compound 4, half-maximal inhibitory concentration: 16 ug/mL
Compound 4: the middle estimate sits 1.1-fold (0.06 log units) below what was measured; the measured number falls inside the stated range.
By their numbers in this assay, from the lowest: compounds 3, 1, 2 and 4 (each within the scatter of the next, the first and the last beyond it).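

For the compounds shown here, replacing the 3,7-dimethylocta-2,6-dien-1-yl chain with 3-methylbut-2-en-1-yl gives the first reading for a change in this chain: in this assay the step is a 1.6-fold higher number from compound 1 to compound 4 (0.20 log units; within the scatter), which stays within the scatter. The 3-methylbut-2-en-1-yl unit that leaves on the saturated chain carbon bound to a double-bonded chain carbon is therefore not needed to keep the number within the scatter of that of compound 1, so these two chain lengths are not separated by this read-out. No measurement accompanies this pair that could account for the reading, and the size of the step stays uninterpreted.

Going by these compounds, it remains open whether a longer chain than 3,7-dimethylocta-2,6-dien-1-yl, a fully saturated alkyl chain, or a chain ending in an amine or a carboxylic acid would move the number beyond the scatter. On these data alone, it is also open how the 3-methylbut-2-en-1-yl chain of compound 4 would read together with the additional hydroxy group carried by compound 2, since the two changes have so far been seen only separately.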